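Swapping a dichlorophenyl for pyrazolylmethyl on the shared core

A few compounds are considered here, and "the series" means these few. Any claim that something is new, unique, unknown or untested is made for them only; others in the source may bear on it.

Measured so far:
Compound 1, `Cc1nn(-c2ncnc3nc[nH]c23)c2c1C(OCc1ccc(Cl)cc1Cl)CC(=O)N2`: 243 nM
Compound 2, `CCCCCCCCOC1CC(=O)Nc2c1c(C)nn2-c1ncnc2nc[nH]c12`: 388 nM
Compound 3, `Cc1nn(-c2ncnc3nc[nH]c23)c2c1C(NC(=O)Cc1cccs1)CC(=O)N2`: 244 nM

All three compounds were tested in a functional assay on HEK293 cells for agonist activity at G-protein coupled receptor 39 (Homo sapiens), read by scintillation proximity assay and inositol phosphate accumulation, with a stated time of 75 min; on this read-out lower numbers stand for an effect already at smaller amounts and higher numbers for an effect only at larger amounts of compound. Compound 1 sits within the scatter of both other numbers: the step of a 1.6-fold higher number from compound 1 to compound 2 (0.20 log units; within the scatter) and the step of a 1.0-fold higher number from compound 1 to compound 3 (0.00 log units; within the scatter) are each too small to count, and the same holds for a 1.6-fold lower number from compound 2 to compound 3 (0.20 log units; within the scatter). So far, then, changing the group that hangs off the shared core has left the read-out essentially flat.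

Among the compounds with values here, compound 4, `Cc1nn(-c2ncnc3nc[nH]c23)c2c1C(OCCn1cccn1)CC(=O)N2`, keeps the core of compound 1 and changes only that hanging group: (1H-pyrazol-1-yl)methyl in place of 2,4-dichlorophenyl on a saturated chain carbon bound to an oxygen on a saturated carbon.

The two steps that speak to this change are those from compound 1 to compound 2 and from compound 1 to compound 3, both within the scatter, because a 1.6-fold higher number from compound 1 to compound 2 (0.20 log units; within the scatter) and a 1.0-fold higher number from compound 1 to compound 3 (0.00 log units; within the scatter) show that even a large exchange at this position barely moved the number. The new group is smaller and carries ring nitrogens that the old one lacked, which the measured set has not yet probed, so a little caution is warranted.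

Compound 4 is therefore expected to give a number close to compound 1, with the step of a 1.4-fold higher number from compound 1 to compound 4 (0.16 log units; within the scatter) judged likely to stay within the scatter. The estimate for compound 4 in this assay is 350 nM, in a range from 120 nM to 1100 nM.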

Compound 4, half-maximal effective concentration: 2270 nM
Beside the measured number, compound 4's estimate is 6.5-fold (0.81 log units) below it; the whole stated range lies below it.
By their numbers in this assay, from the lowest: compounds 1, 3 and 2 (each within the scatter of the next); then compound 4.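

Among the compounds shown, only this exchange moves the number beyond the scatter in this assay, with a 9.3-fold higher number from compound 1 to compound 4 (0.97 log units; beyond the scatter) and a 9.3-fold higher number from compound 3 to compound 4 (0.97 log units; beyond the scatter), as well as a 5.9-fold higher number from compound 2 to compound 4 (0.77 log units; beyond the scatter). The position is therefore not indifferent to what it carries: (2,4-dichlorobenzyl)oxy, octyloxy and (((thiophen-2-yl)methyl)carbonyl)amino in compound 1, compound 2 and compound 3 give numbers within the scatter of one another, while 2-(1H-pyrazol-1-yl)ethoxy in compound 4 stands clearly apart. The change replaces a six-membered aromatic ring of carbon only, with its two chlorines, by a five-membered aromatic ring with 2 hetero atoms, but no measurement at hand says which part of this exchange accounts for the higher number.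

The compounds shown leave open whether the ring nitrogens, the missing chlorines or the different link to the ring matters most, and a 2-phenylethoxy group in the same place would help to separate these. They also leave open how a chain ending in an amine or a carboxylic acid would fare here.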